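The source may hold more compounds than are shown below. What is called first, only, known or untested is meant among the compounds shown, and "the series" means these compounds.

Measured so far:
compound 1, `CCc1ccc(NC2=CC(=O)c3c(nc4n3[C@H]3OC[C@@H](O)[C@H]3OC4)C2=O)cc1` — 8990 nM
compound 2, `O=C1C(N2CCCCC2)=CC(=O)c2c1nc1n2[C@H]2OC[C@@H](O)[C@H]2OC1` — > 8000 nM
compound 3, `Cc1ccc(NC2=CC(=O)c3nc4n(c3C2=O)[C@H]2OC[C@@H](O)[C@H]2OC4)cc1` — 1660 nM

The study concerns a set of compounds sharing one core, tested in a functional assay on MCF7 cells (Homo sapiens) for inhibition, read by sulforhodamine B assay; on this read-out lower numbers stand for stronger inhibition and higher numbers for weaker inhibition. Compound 1 gives 8990 nM in this assay. Compound 3 gives 1660 nM in this assay. Of the two numbers shown, compound 1 carries the highest, and compound 3 stands a step beyond the scatter lower. Compound 2 is reported only as a limit in this assay, > 8000 nM. Because of the limit of > 8000 nM in this assay, at which 1 of the 3 values shown sits, the step that the limit leaves unreadable from compound 1 to compound 2 cannot be read.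

The unmeasured compound 4, `CCCc1ccc(NC2=CC(=O)c3c(nc4n3[C@H]3OC[C@@H](O)[C@H]3OC4)C2=O)cc1`, differs from compound 1 in one place: methyl in place of hydrogen on a saturated chain carbon, two bonds along the chain from an aromatic carbon. None of the measured steps concerns this particular change; the only step shown, from compound 1 to compound 2, replaces the whole aryl amine and is itself unreadable. The shown values of compound 1 and compound 3 differ in more than one place and cannot be read as a single step either.

For the measured compounds named here, with no measured step bearing on this change, a step of the size a 1.1-fold lower number from compound 1 to compound 4 (0.05 log units; within the scatter) is expected, which stays within the scatter. Compound 4 is therefore estimated at 8000 nM in this assay, with a range from 3000 nM to 20000 nM.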

Compound 4, half-maximal inhibitory concentration: > 4000 nM
Compound 4 gave a limit, no number; the forecaster's own chance of this, stated with the estimate: 30%; the middle value lies beyond the limit too.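

In this assay, compound 4 is reported only as a limit, > 4000 nM. No new step can be read from this result, and the change from compound 1 to compound 4 stays without a size, because the value is a limit: the limit of > 4000 nM in this assay, at which 1 of the 4 values shown sits.

The compounds shown leave open how far, and in which direction, going from 4-ethylphenyl to 4-propylphenyl moves the result in this assay.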